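This account rests on a few compounds, and the source may have more. Where it says the series, first, only, none or still open, it means among the compounds named here.

In a functional assay on KB cells (Homo sapiens) for cytotoxicity, read by resazurin assay, with a stated time of 3 days (on this read-out higher numbers stand for weaker inhibition and lower numbers for stronger inhibition), compound 1 `CCCCCC(=O)NCC(C)(C)CC1=C(O)C(=O)c2ccccc2C1=O` gives 40200 nM, while compound 2 `CCCCCCCCCCC(=O)NCC(C)(C)CC1=C(O)C(=O)c2ccccc2C1=O` gives 17600 nM, the lower of the two numbers. Compound 3 `CCCCCCCCCCCC(=O)NCC(C)(C)CC1=C(O)C(=O)c2ccccc2C1=O` extends the chain of compound 2 by a single change: methyl in place of hydrogen on a saturated chain carbon, ten or more bonds along the chain from a carbonyl carbon. For the measured compounds named here, the only measured step that bears on this is modest: a 2.3-fold lower number from compound 1 to compound 2 (0.36 log units; beyond the scatter). That step added pentyl, a much larger piece than methyl, so only a slight further fall is expected in this assay, one probably lost in the scatter. The expected change is a 1.2-fold lower number from compound 2 to compound 3 (0.07 log units; within the scatter). The estimated value for compound 3 is 15000 nM, with an expected range of 7500 nM to 30000 nM.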

Compound 3, half-maximal inhibitory concentration: 12800 nM
Estimate against measurement, compound 3: 1.2-fold (0.07 log units) above, within the range that was stated.
By their numbers in this assay, from the lowest: compounds 3 and 2 (each within the scatter of the next); then compound 1.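

In this assay, methyl in place of hydrogen on a saturated chain carbon gives a 1.4-fold lower number from compound 2 to compound 3 (0.14 log units; within the scatter) and so cannot be told apart from no change. Hexyl in place of hydrogen, five bonds along the chain from a carbonyl carbon, gives a 3.1-fold lower number from compound 1 to compound 3 (0.50 log units; beyond the scatter) as a modest change, so only the larger addition can be read. Nothing measured here explains either step. From the compounds shown here alone, whether a longer chain would lower the number further remains open. So does the effect of an amine or a carboxylic acid in place of this methyl.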